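A few compounds are considered here, and "the series" means these few. Any claim that something is new, unique, unknown or untested is made for them only; others in the source may bear on it.

In a functional assay on the whole organism for inhibition, with Rattus norvegicus as the target, at a dose of 3 mg/kg by the oral route (on this read-out higher numbers stand for a stronger effect at the one dose given and lower numbers for a weaker effect), three compounds of a shared core have been measured. Compound 1 `O=C(Nc1nn[nH]n1)c1cccc(Br)n1` gives 38%, compound 2 `CC(C)c1ccnc(C(=O)Nc2nn[nH]n2)c1` gives 34%, and compound 3 `COc1cccc(C(=O)Nc2nn[nH]n2)n1` gives 36%. For the measured compounds named here, the three numbers lie within the scatter of one another, so compound 3 cannot be set apart from either of the others; the single one-place step a number 2 percentage points lower from compound 1 to compound 3 (within the scatter) is likewise within the scatter. Compound 4 `O=C(Nc1nn[nH]n1)c1ccccn1` has not yet been measured. It differs from compound 3 in one place: hydrogen in place of methoxy on an aromatic carbon. Going by the values given here, the only measured step bearing on this is the exchange of bromo for methoxy at the same aromatic carbon, and that exchange moved the read-out by an amount inside the scatter. Among the compounds with values here, nothing measured so far has shifted the number beyond the scatter, so the step of a number 1 percentage points lower from compound 3 to compound 4 (within the scatter) is expected to stay within it as well. On that basis compound 4 is estimated at 35%, with a range from 22% to 48%.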

Compound 4, a percentage reported as inhibition, in the whole organism at one dose (the size of the read-out at that dose, not a potency): 29%
Estimate against measurement, compound 4: 6 percentage points above; low and high end bracket the measured number.
By their numbers in this assay, from the lowest: compounds 4, 2, 3 and 1 (each within the scatter of the next).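

With hydrogen on the aromatic carbon next to the ring nitrogen, the bromo and methoxy compounds gain a reference point in this assay: replacing methoxy gives a number 7 percentage points lower from compound 3 to compound 4 (within the scatter) and replacing bromo gives a number 9 percentage points lower from compound 1 to compound 4 (within the scatter) and so neither group can be told apart from hydrogen at this position. Hydrogen in place of isopropyl gives a number 5 percentage points lower from compound 2 to compound 4 (within the scatter) and thus all three groups of the set remain inseparable from the unsubstituted compound, even though these steps are larger than the one between bromo and methoxy. No measurement available here accounts for these numbers.

On these data alone, whether any group on this carbon can move the read-out beyond the scatter remains open. An amine, a carboxylic acid or a longer chain would test this, and the single dose leaves potency unresolved.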